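Lengthening and Capping the Acid Chain in a Cyclobutyl Prostanoid Series

A few compounds are considered here, and "the series" means these few. Any claim that something is new, unique, unknown or untested is made for them only; others in the source may bear on it.

Compound 1, `CCCC1([C@H](O)/C=C/C2[C@H](O)CC(=O)[C@@H]2C/C=C\CCCC(=O)O)CCC1`: 0.003 mg/kg
Compound 2, `CCCCC1([C@@H](O)/C=C/C2[C@H](O)CC(=O)[C@@H]2CCCCCCC(=O)O)CCC1`: 0.0439 mg/kg
Compound 3, `CCCCC1([C@H](O)/C=C/C2CCC(=O)[C@@H]2CCCCCC(=O)O)CCC1`: 0.032 mg/kg

Of the compounds shown here, three have been measured in a functional assay on the whole organism (strain Hartley) for inhibition, with Cavia porcellus as the target, with stated times of 15 min and 2 min; a higher number here means that more compound is needed for the effect, a lower number that less compound is needed. Compound 3, `CCCCC1([C@H](O)/C=C/C2CCC(=O)[C@@H]2CCCCCC(=O)O)CCC1`, gives 0.032 mg/kg, the second highest of the three numbers. Its nearest neighbour is compound 2, whose value of 0.0439 mg/kg lies within the scatter of compound 3. Compound 1 stands furthest away, with 0.003 mg/kg, a gap that is beyond the scatter.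

Compound 4, `CCCCC1([C@H](O)/C=C/C2CCC(=O)[C@@H]2CCCCCCCCC(=O)OCC)CCC1`, has not yet been measured. It differs from compound 3 in one place: 3-(ethoxycarbonyl)propyl in place of carboxy on a saturated chain carbon, five bonds along the chain from a saturated ring carbon. Within the data shown here, no measured pair in this set shows this kind of change, so nothing here tells how large its effect will be. Because compound 3 gives 0.032 mg/kg, and the change leaves the rest of the molecule untouched, a modest rise in the number is expected rather than a large move in either direction. The step from compound 3 to compound 4 is expected to be a 1.9-fold higher number from compound 3 to compound 4 (0.27 log units; within the scatter). For compound 4 the expected value in this assay is 0.06 mg/kg, within a range from 0.015 mg/kg to 0.3 mg/kg.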

Compound 4, dose for half-maximal effect: 4.38 mg/kg
For compound 4 the middle estimate is 73-fold (1.86 log units) below the measured one; measured number outside the range, above it.
By their numbers in this assay, from the lowest: compound 1; then compounds 3 and 2 (each within the scatter of the next); then compound 4.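

In this assay, putting 3-(ethoxycarbonyl)propyl in place of carboxy on a saturated chain carbon, five bonds along the chain from a saturated ring carbon, gives a 140-fold higher number from compound 3 to compound 4 (2.14 log units; beyond the scatter). Among these compounds, this is the first single-place change in the set, and it shows that the dose needed for the effect responds strongly to what stands at this position. Nothing at hand accounts for the size of this step.

The change lengthens the chain and replaces the free acid with an ethyl ester in one move, so the compounds shown cannot divide the step between the two. Still open, as far as these compounds go, is whether 3-carboxypropyl, a longer chain that keeps the carboxylic acid, would stay close to compound 3, or whether ethoxycarbonyl on the original chain would alone raise the number.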